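The source may report more compounds than this note shows. Statements on the series, on what has been measured and on what is new or still open speak of the compounds shown alone.

Working notes on the series. The shared core carries two arylidene arms; compound 1 `COc1ccccc1/C=c1\c(=O)[nH]/c(=C/c2cccc(Cl)c2Cl)c(=O)n1C` bears 2-methoxyphenyl on one arm and 2,3-dichlorophenyl on the other. In a functional assay on NCI-H1975 cells (Homo sapiens) for cytotoxicity, read by CCK-8 assay, with a stated time of 72 h (on this read-out lower numbers stand for stronger inhibition and higher numbers for weaker inhibition), compound 1 gives 300 nM, the lowest of the two numbers recorded so far. Compound 2 `C=CCn1c(=O)/c(=C\c2cc(F)ccc2C)[nH]c(=O)/c1=C\c1ccccc1OC` gives 7300 nM in this assay, a higher number than compound 1 and beyond the scatter. Compound 3 `C=CCn1c(=O)/c(=C\c2ccc(C)cc2)[nH]c(=O)/c1=C\c1ccccc1OC` is recorded as "not active" (no number reported) in this assay, with no number behind it. Both compound 2 and compound 3 differ from compound 1 in more than one place, so no single-change step can be read from them.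

Compound 4 `COc1ccccc1/C=c1/[nH]c(=O)/c(=C\c2ccccc2OC)n(C)c1=O` awaits measurement. Against compound 1 the change is 2-methoxyphenyl in place of 2,3-dichlorophenyl on a double-bonded chain carbon bound to an aromatic carbon. The two weaker entries, compound 2 and compound 3, each carry a different aryl group at this arm together with other changes, so what the aryl itself contributes is not separable. A step towards a higher number, of moderate size, is expected in this assay, the estimated step being a 6.7-fold higher number from compound 1 to compound 4 (0.82 log units; beyond the scatter). Compound 4 is expected near 2000 nM, within a range of 500 nM to 10000 nM.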

Compound 4, half-maximal inhibitory concentration: 16900 nM
Beside the measured number, compound 4's estimate is 8.5-fold (0.93 log units) below it; the whole stated range lies below it.
By their numbers in this assay, from the lowest: compound 1; then compound 2; then compound 4.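

Among these compounds, with the rest of compound 1 held fixed, this arm gives the first single-change reading: in this assay, 2-methoxyphenyl in place of 2,3-dichlorophenyl on a double-bonded chain carbon bound to an aromatic carbon gives a 56-fold higher number from compound 1 to compound 4 (1.75 log units; beyond the scatter). The aryl group at this position therefore moves the number substantially on its own, which compounds 2 and 3, with their several simultaneous changes, could not show. No supporting measurement accounts for the size of this step.

On these data alone, whether the step follows from losing the two chlorine atoms or from gaining the methoxy group remains open. Also open, as far as these compounds go, is how a phenyl group carrying a single chlorine, a trifluoromethyl group or a nitrile would fare on this arm.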